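Taking the bromo group off compound 2

The source may hold more compounds than are shown below. What is called first, only, known or untested is meant among the compounds shown, and "the series" means these compounds.

In a functional assay on HUVEC cells (Homo sapiens) for inhibition, read by ELISA and BrdU incorporation (on this read-out lower numbers stand for stronger inhibition and higher numbers for weaker inhibition), compound 1 (`Cc1cccc(C(=O)Nc2cnc3ccccc3c2)c1Br`) gives 11.6 nM and compound 2 (`Cc1cc(Br)cc(C(=O)Nc2cnc3ccccc3c2)c1O`) gives 18.9 nM so compound 2 stands within the scatter of compound 1 and the two cannot be told apart.

The next step leads to compound 3 (`Cc1cccc(C(=O)Nc2cnc3ccccc3c2)c1O`) with hydrogen in place of bromo on an aromatic carbon at a site meta to a large group, meta to a methyl group and para to a hydroxy group.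

For the measured compounds named here, no measured pair isolates this change, so the data give no direct size for it. Compound 3 alone lacks a bromo group, while both measured compounds carry one. A small move towards weaker inhibition is expected in this assay of about the size of the scatter, though a larger loss cannot be excluded. The expected change is a 1.7-fold higher number from compound 2 to compound 3 (0.23 log units; within the scatter) on this estimate. For compound 3 the estimated value is 32 nM with a range of 10 nM to 100 nM as expected.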

Compound 3, half-maximal inhibitory concentration: 35.7 nM
Compound 3: the middle estimate sits 1.1-fold (0.05 log units) below what was measured, and the stated range covers the measured number.
By their numbers in this assay, from the lowest: compounds 1, 2 and 3 (each within the scatter of the next, the first and the last beyond it).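

In this assay the first direct read at the site para to a hydroxy group is a 1.9-fold higher number from compound 2 to compound 3 (0.28 log units; within the scatter) with hydrogen in place of bromo, so this change stays within the scatter and the two compounds cannot be told apart. The series also gains its first step beyond the scatter: a 3.1-fold higher number from compound 1 to compound 3 (0.49 log units; beyond the scatter) as a modest change, where a hydroxy group stands in the place of the bromo group of compound 1, while compound 2 lies within the scatter of both other compounds. No independent measurement bears on either step, so the numbers stand without an explanation.

The compounds shown leave open whether another group at the site para to a hydroxy group, such as chloro, methoxy or an amine, would give a step beyond the scatter from compound 3. They also leave open what a methoxy group or a carboxylic acid would give in place of the hydroxy group of compound 3, and so how far the step seen with hydroxy in place of bromo extends to other groups.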